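Replacing a fluorinated phenyl with a methylpyridinyl on the amide nitrogen

This account rests on a few compounds, and the source may have more. Where it says the series, first, only, none or still open, it means among the compounds named here.

Among the measured compounds shown here, compound 2 `Cc1cccc(F)c1N(C)C(=O)c1ccc(-c2ccc(O)cc2)o1` gives 120 nM in an assay on T47D cells for inhibition of 17-beta-hydroxysteroid dehydrogenase type 1 (Homo sapiens), read by HPLC, with a stated time of 24 h (a lower number here means a stronger inhibitor, a higher number a weaker inhibitor), the lower of the two numbers known; compound 1 `Cc1ccccc1N(C)C(=O)c1ccc(-c2ccccc2O)o1` gives 1900 nM, a gap that lies beyond the scatter. Compound 3 `Cc1ncccc1N(C)C(=O)c1ccc(-c2ccc(O)cc2)o1` has not been measured. It differs from compound 2 by 2-methylpyridin-3-yl in place of 2-fluoro-6-methylphenyl on an amide-type nitrogen. For the measured compounds named here, no measured pair shows this change, so the direction must be guessed from the two values alone. For compound 3 a modest step toward weaker inhibition is expected, a 2.1-fold higher number from compound 2 to compound 3 (0.32 log units; beyond the scatter), roughly at the edge of the scatter. Compound 3 is therefore estimated at 250 nM, with a likely range from 80 nM to 800 nM.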

Compound 3, half-maximal inhibitory concentration: 43 nM
For compound 3 the middle estimate is 5.8-fold (0.76 log units) above the measured one; the whole stated range lies above it.
By their numbers in this assay, from the lowest: compound 3; then compound 2; then compound 1.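

In this assay, 2-methylpyridin-3-yl in place of 2-fluoro-6-methylphenyl on the amide-type nitrogen gives stronger inhibition (a 2.8-fold lower number from compound 2 to compound 3 (0.45 log units; beyond the scatter)). This position therefore accepts an aromatic ring with a hetero atom and a hydrogen-bond acceptor, and the fluorine is not needed for inhibition at this level. Nothing available accounts for the gain. The compounds shown leave open whether the ring nitrogen, the loss of fluorine, or both carry this step. They also leave open how a pyridine ring carrying a methoxy group or an amine in place of the methyl would behave.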